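Swapping a Methoxyethyl Ester for a Cyclohexyl Ester

The source may hold more compounds than are shown below. What is called first, only, known or untested is meant among the compounds shown, and "the series" means these compounds.

Three esters of one shared core have been tested in a functional assay on Vero cells (Chlorocebus sabaeus) for cytotoxicity; a higher number here means that more compound is tolerated, a lower number that less compound is tolerated. Compound 1 `CCCCCCCCOC(=O)C(O)Cn1cnc2c(N)ncnc21` gives 200 ug/mL and compound 2 `CCCCOC(=O)C(O)Cn1cnc2c(N)ncnc21` gives 200 ug/mL, a change of no change at the digits printed from compound 1 to compound 2 (within the scatter). Compound 3 `COCCOC(=O)C(O)Cn1cnc2c(N)ncnc21` reaches only a limit of the assay, > 400 ug/mL, so its true number is not known. Within the data shown here, it is the one value sitting at the limit of > 400 ug/mL in this assay, at which 1 of the 3 values shown sits. The steps toward it were an at least 2.0-fold higher number from compound 1 to compound 3 (0.30 log units; that floor lies within the scatter) and an at least 2.0-fold higher number from compound 2 to compound 3 (0.30 log units; that floor lies within the scatter), both at a floor that lies within the scatter.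

Compound 4 `Nc1ncnc2c1ncn2CC(O)C(=O)OC1CCCCC1` carries cyclohexyl in place of 2-methoxyethyl on an oxygen next to a carbonyl group. This runs opposite to those two steps: the 2-methoxyethyl group leaves and a six-membered ring of carbon only enters, making compound 4 resemble compound 1 and compound 2 more than compound 3. An expected step of an at least 2.0-fold lower number from compound 3 to compound 4 (0.30 log units; that floor lies within the scatter) would bring compound 4 back to the level of compound 1 and compound 2. Compound 4 is thus estimated at 200 ug/mL, with a likely range from 100 ug/mL to 400 ug/mL.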

Compound 4, minimum cytotoxic concentration: 100 ug/mL
Compound 4: the middle estimate sits 2.0-fold (0.30 log units) above what was measured; low and high end bracket the measured number.
By their numbers in this assay, from the lowest: compounds 4, 1 and 2 (each within the scatter of the next). At a limit, above all of these: compound 3.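

In this assay, among these compounds, placing cyclohexyl in place of 2-methoxyethyl on an oxygen next to a carbonyl group gives an at least 4.0-fold lower number from compound 3 to compound 4 (0.60 log units; beyond the scatter), the only step in this set printed as beyond the scatter. Among the compounds shown here, compound 3 has no exact number, because its value is a limit: the limit of > 400 ug/mL in this assay, at which 1 of the 4 values shown sits. Against the open-chain esters, the cyclohexyl ester gives a 2.0-fold lower number from compound 2 to compound 4 (0.30 log units; within the scatter) and a 2.0-fold lower number from compound 1 to compound 4 (0.30 log units; within the scatter), so cyclohexyl cannot be told apart from butyl or octyl here, and compound 4 is the only compound clearly separated from compound 3.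

As far as these compounds go, what remains open is whether the separation follows the oxygen of the 2-methoxyethyl group, the ring of compound 4, or neither. A tetrahydropyranyl ester or an ester ending in an amine could show whether such groups stand with compound 3 or with compound 4.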